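A few compounds are considered here, and "the series" means these few. Any claim that something is new, unique, unknown or untested is made for them only; others in the source may bear on it.

Measured compounds:
compound 1, `Cc1cccc(Cn2c(CN3CCN(C(=O)c4ccc([N+](=O)[O-])cc4)CC3)nc3ccccc32)c1`, with 24.3% in an assay on isolated protein for inhibition of aldehyde dehydrogenase 1A1 (Homo sapiens), read by spectrophotometry, tested at 10 uM; a lower number here means less inhibition, a higher number more inhibition at the concentration tested (going by the name of the read-out);
compound 2, `O=C(C1CC1)N1CCN(Cc2nc3ccccc3n2Cc2cccc(F)c2)CC1`, with 27.2%;
compound 3, `CC(C)CCn1c(CN2CCN(C(=O)C3CC3)CC2)nc2ccccc21`, with 70%.

Compound 1 gives the lowest of the three numbers. Compound 2 stands nearest, within the scatter of compound 1, so the two cannot be ordered. Compound 3 stands furthest, beyond the scatter.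

Compound 4, `Cc1cccc(Cn2c(CN3CCN(C(=O)c4ccncc4)CC3)nc3ccccc32)c1`, is not yet measured. It differs from compound 1 in one place: pyridin-4-yl in place of 4-nitrophenyl on a carbonyl carbon.

For the measured compounds named here, only one step between measured compounds is known, a number 42.8 percentage points higher from compound 2 to compound 3 (beyond the scatter). That step changes the group on a saturated chain carbon bound to an aromatic nitrogen, not the group on the carbonyl carbon, so it does not bear on the change from compound 1 to compound 4. Going by the values given here, no measured pair shows the carbonyl substituent varied, so there is nothing to set a direction from. The expectation is therefore a step of a number 0.7 percentage points higher from compound 1 to compound 4 (within the scatter), not beyond the scatter. Compound 4 is estimated at 25%, between 8% and 45%.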

Compound 4, a percentage reported as inhibition, at one concentration (the size of the read-out at that concentration, not a potency): 20.6%
Compound 4: the middle estimate sits 4.4 percentage points above what was measured; measured number inside the range.
By their numbers in this assay, from the lowest: compounds 4, 1 and 2 (each within the scatter of the next); then compound 3.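

In this assay, for the compounds shown here, this is the first pair in which the group on the carbonyl carbon is varied, and exchanging 4-nitrophenyl for pyridin-4-yl gives a number 3.7 percentage points lower from compound 1 to compound 4 (within the scatter). At this position, then, the two groups cannot be told apart in this assay, even though the entering group has fewer heavy atoms, no double bond outside the ring and a nitrogen within its aromatic ring. No independent evidence bears on why the two groups read alike.

The compounds shown leave open whether a group of another kind on the carbonyl carbon, such as a carboxylic acid, an amine or a longer alkyl chain, would move the number beyond the scatter. They also leave open whether pyridin-4-yl and 4-nitrophenyl would read alike alongside the isobutyl-bearing chain of compound 3.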